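Chloro in place of trifluoromethyl on compound 2

The compounds below may be only part of what the source reports. "The series", "measured", "known", "first", "only" and "open" are said of these compounds alone.

Of the compounds shown here, two have so far been measured in a functional assay on SK-MEL-28 cells (Homo sapiens) for inhibition, read by sulforhodamine B assay, with a stated time of 48 h, tested at 10 uM; on this read-out lower numbers stand for a stronger effect and higher numbers for a weaker effect at the one concentration tested. Compound 1 `COc1cc(Cl)cc(-c2nn(-c3cccc(NC(=O)c4ccc(Cl)c(Cl)c4)c3)cc2-c2ccncc2)c1` gives 87.8%, while compound 2 `O=C(Nc1cccc(-n2cc(-c3ccncc3)c(-c3cc(O)cc(Cl)c3)n2)c1)Nc1ccc(Cl)c(C(F)(F)F)c1` gives -13.5%, the lowest of the two numbers and separated from compound 1 by a gap beyond the scatter. Compound 3 `O=C(Nc1cccc(-n2cc(-c3ccncc3)c(-c3cc(O)cc(Cl)c3)n2)c1)Nc1ccc(Cl)c(Cl)c1` has not yet been measured; it differs from compound 2 by chloro in place of trifluoromethyl on an aromatic carbon. For the measured compounds named here, no step between measured compounds anchors this change, so the step of a number 13.5 percentage points higher from compound 2 to compound 3 (beyond the scatter) is expected to be small, within the scatter in either direction. Compound 3 is therefore estimated at 0%, with a range from -30% to 40%.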

Compound 3, a percentage reported as activity, at one concentration (the size of the read-out at that concentration, not a potency): -50.9%
Beside the measured number, compound 3's estimate is 50.9 percentage points above it, and the stated range ends above it.
By their numbers in this assay, from the lowest: compound 3; then compound 2; then compound 1.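

In this assay, the aromatic carbon ortho to a chloro group proves sensitive to this change: chloro in place of trifluoromethyl brings a number 37.4 percentage points lower from compound 2 to compound 3 (beyond the scatter) and so a stronger effect at the one concentration tested. For the compounds shown here, as the first step between compounds that differ in one place, it ties a difference in the read-out to this position alone. Nothing available accounts for the size of this step.

On these data alone, whether bromo, methyl or methoxy on this carbon would give a number nearer compound 2 or compound 3 stays open. So does whether the same change would give a step of similar size on another core.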